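Swapping a Naphthalenyl Group for a Bromophenyl Group

A few compounds are considered here, and "the series" means these few. Any claim that something is new, unique, unknown or untested is made for them only; others in the source may bear on it.

Compound 3 `c1ccc2c(-c3cn4ccnc4c(-c4ccc5ncn(C6CCCCC6)c5c4)n3)cccc2c1` is the lowest of the three compounds measured in a functional assay on NCI-H23 cells (Homo sapiens) for inhibition, read by sulforhodamine B assay, with a stated time of 48 h, tested at 10 uM (on this read-out lower numbers stand for less inhibition and higher numbers for more inhibition at the one concentration tested (going by the name of the read-out)), where compound 3 gives 4.32%. Its nearest neighbour is compound 1 `Brc1cn2ccnc2c(-c2ccc3ncn(C4CCCCC4)c3c2)n1`, which gives 10.2%; the step of a number 5.9 percentage points lower from compound 1 to compound 3 (within the scatter) stays within the scatter, so these two cannot be ranked against each other. Far from both stands compound 2 `O=Cc1ccc(-c2cn3ccnc3c(-c3ccc4ncn(C5CCCCC5)c4c3)n2)cc1`, which gives 54.5%; the step of a number 50.2 percentage points lower from compound 2 to compound 3 (beyond the scatter) and the step of a number 44.3 percentage points higher from compound 1 to compound 2 (beyond the scatter) mark compound 2 as the one clear high reading.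

Compound 4 `Brc1ccc(-c2cn3ccnc3c(-c3ccc4ncn(C5CCCCC5)c4c3)n2)cc1` has not yet been measured. It differs from compound 3 in one place: 4-bromophenyl in place of naphthalen-1-yl on an aromatic carbon. Compound 4 thus carries a single six-membered aromatic ring at that position, as compound 2 does, but with bromine where compound 2 has a formyl group. Compound 2 shows that a one-ring group there can give a large reading, whereas compound 1 and compound 3 show low readings for bromo alone and for the two-ring naphthalen-1-yl. Within the data shown here, no measured step mirrors this exact change, so the forecast is uncertain and leans on these two ends. For compound 4 a moderate rise is expected, a number 20.7 percentage points higher from compound 3 to compound 4 (beyond the scatter). For compound 4 the estimated value in this assay is 25%, likely between 5% and 55%.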

Compound 4, a percentage reported as inhibition, at one concentration (the size of the read-out at that concentration, not a potency): 8.38%
Estimate against measurement, compound 4: 16.6 percentage points above; the range from low to high includes it.
By their numbers in this assay, from the lowest: compounds 3, 4 and 1 (each within the scatter of the next); then compound 2.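

In this assay, swapping the two-ring naphthalen-1-yl for the one-ring 4-bromophenyl gives no reading that can be told apart (a number 4.1 percentage points higher from compound 3 to compound 4 (within the scatter)), and the same holds when 4-bromophenyl takes the place of bromo alone (a number 1.8 percentage points lower from compound 1 to compound 4 (within the scatter)). A single six-membered aromatic ring at this position is therefore not enough for a high reading, and neither compound 1 nor compound 3 can be ranked against compound 4. The large gap between the two one-ring compounds (a number 46.1 percentage points lower from compound 2 to compound 4 (beyond the scatter)) ties the high reading of compound 2 to the formyl group rather than to the phenyl ring alone, but no measurement here explains why this group stands apart.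

On these data alone, whether a nitrile, a carboxylic acid or an amine in place of the formyl group would bring the reading near that of compound 2 at 54.5% remains open. So does the question of whether the high reading is particular to the formyl group or would be shared by other groups in its place, as only bromine and the formyl group can be compared on this phenyl ring.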